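This account rests on a few compounds, and the source may have more. Where it says the series, first, only, none or still open, it means among the compounds named here.

In a functional assay on SK-BR-3 cells (Homo sapiens) for antiproliferative activity, read by MTT assay, with a stated time of 72 h (a higher number here means a weaker inhibitor, a lower number a stronger inhibitor), compound 1 `C/C=C1/[C@H](O[C@@H]2O[C@H](CO)[C@@H](O)[C@H](O)[C@H]2O)OC=C(C(=O)OC)[C@H]1CC(=O)OCCCCCCCCCCCCCCC` gives 1600 nM. Compound 2 `C#CCOC(=O)C[C@@H]1C(C(=O)OC)=CO[C@@H](O[C@@H]2O[C@H](CO)[C@@H](O)[C@H](O)[C@H]2O)/C1=C/C` gives no number in this assay, only a limit of the assay, > 15000 nM. Compound 3 `C/C=C1/[C@H](O[C@@H]2O[C@H](CO)[C@@H](O)[C@H](O)[C@H]2O)OC=C(C(=O)OC)[C@H]1CC(=O)OCCC` differs from compound 2 in one place, with ethyl in place of ethynyl on a saturated chain carbon bound to an oxygen next to a carbonyl group, so that propargyloxycarbonyl becomes propoxycarbonyl (ethyl in place of ethynyl on a saturated chain carbon bound to an oxygen next to a carbonyl group). For the measured compounds named here, no measured step bears on this change, so no move beyond the scatter is expected in this assay, and the expected step that the limit leaves unreadable from compound 2 to compound 3 is small. For compound 3 the estimated value is 18000 nM, within a range of 7000 nM to 45000 nM.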

Compound 3, half-maximal inhibitory concentration: > 15000 nM
Compound 3 gave a limit, no number (the forecaster's own chance of this, stated with the estimate: 60%); the middle value lies beyond the limit too.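

The change from ethynyl to ethyl cannot be read in this assay, since compound 2 and compound 3 both stand at a limit and not at a number: the limit of > 15000 nM in this assay, at which 2 of the 3 values shown sit. Compound 3 does give a comparison between two saturated chains, which compound 2 with its triple bond did not: with hydrogen in place of dodecyl, the result is an at least 9.3-fold higher number from compound 1 to compound 3 (0.97 log units; beyond the scatter). The compounds shown leave open how the values run for chains of intermediate length, between propyl and the chain of compound 1. They also leave open what an amine or a carboxylic acid at the chain end would give.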